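Methylphenyl positional change on the fused core, agonist potency

This account rests on a few compounds, and the source may have more. Where it says the series, first, only, none or still open, it means among the compounds named here.

Measured so far:
compound 1 `CC#CC(CC(=O)O)c1ccc(OCc2ccc3nc(-c4ccc(CC)cc4)cn3c2)cc1`, 496 nM
compound 2 `CC#CC(CC(=O)O)c1ccc(OCc2ccc3nc(-c4ccccc4C)cn3c2)cc1`, 389 nM
compound 3 `CC#CC(CC(=O)O)c1ccc(OCc2ccn3cc(-c4ccc(C)cc4C)nc3c2)cc1`, 503 nM

In an assay on isolated protein for agonist activity at Free fatty acid receptor 1 (Homo sapiens) (on this read-out higher numbers stand for an effect only at larger amounts of compound and lower numbers for an effect already at smaller amounts), compound 2 gives the lowest of the three numbers, but its gaps to both neighbours are within the scatter: compound 1 gives 496 nM and compound 3, whose core has the same atoms joined differently, gives 503 nM. The three compounds therefore sit on one level as far as this assay can tell.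

For the measured compounds named here, the only single-point step among them runs a 1.3-fold lower number from compound 1 to compound 2 (0.11 log units; within the scatter) and stays within the scatter.

Compound 4 `CC#CC(CC(=O)O)c1ccc(OCc2ccc3nc(-c4cccc(C)c4)cn3c2)cc1` is not yet measured. It differs from compound 2 by 3-methylphenyl in place of 2-methylphenyl on an aromatic carbon. Going by the values given here, the step from compound 1 to compound 2, which also moved a methyl-bearing phenyl around on the same aromatic carbon, gave no change beyond the scatter, and nothing among the measured compounds points to a shift in either direction for this exchange. The expected step is therefore a 1.2-fold higher number from compound 2 to compound 4 (0.06 log units; within the scatter), that is, none beyond the scatter. For compound 4 the expected value in this assay is 450 nM, with a range from 220 nM to 900 nM.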

Compound 4, half-maximal effective concentration: 1050 nM
Estimate against measurement, compound 4: 2.3-fold (0.37 log units) below; measured number outside the range, above it.
By their numbers in this assay, from the lowest: compounds 2, 1 and 3 (each within the scatter of the next); then compound 4.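

In this assay, the aromatic carbon next to the ring nitrogen proves sensitive to where the methyl sits on the phenyl: with the same atoms joined differently, 3-methylphenyl in place of 2-methylphenyl gives a 2.7-fold higher number from compound 2 to compound 4 (0.43 log units; beyond the scatter), one of the only two steps beyond the scatter among the compounds shown. Replacing 4-ethylphenyl with 3-methylphenyl at the same place gives a 2.1-fold higher number from compound 1 to compound 4 (0.33 log units; beyond the scatter), so compound 4 stands apart from both compounds that differ from it in this one place, although those two lie within the scatter of each other. Nothing available explains why the 3-methylphenyl exchange shifts the number.

Still open, as far as these compounds go, is whether another group on the same phenyl position, such as 3-ethylphenyl, 3-methoxyphenyl or 3-chlorophenyl, would follow compound 4 or return to the level of compound 2. Also open, from the compounds shown here alone, is whether the shared core of compound 1, compound 2 and compound 4 is needed for this sensitivity, since compound 3 differs from each of them in more than one place and offers no direct comparison.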